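Two Measured Compounds and a Trimethoxyphenyl Change

The compounds below may be only part of what the source reports. "The series", "measured", "known", "first", "only" and "open" are said of these compounds alone.

Compound 1 `COc1cc(/C=C/C(=O)/C=C/c2cccc3ccccc23)ccc1OCc1cn(CCCOc2cc(=O)oc3ccccc23)nn1` gives 66%
Compound 2 `COc1ccc(/C=C/C(=O)/C=C/c2ccc(OCc3cn(CCCOc4cc(=O)oc5ccccc45)nn3)c(OC)c2)cc1` gives 54%

In a functional assay on HCT-116 cells (Homo sapiens) for inhibition, read by sulforhodamine B assay, with a stated time of 48 h, tested at 50 uM (on this read-out higher numbers stand for more inhibition of growth at the one concentration tested and lower numbers for less inhibition of growth), compound 2 stands at 54% and is the lower of the two. Compound 3 `COc1cc(/C=C/C(=O)/C=C/c2cc(OC)c(OC)c(OC)c2)ccc1OCc1cn(CCCOc2cc(=O)oc3ccccc23)nn1` differs from compound 2 in one group: 3,4,5-trimethoxyphenyl in place of 4-methoxyphenyl on a double-bonded chain carbon bound to a double-bonded chain carbon with 3,4,5-trimethoxyphenyl in place of 4-methoxyphenyl on a double-bonded chain carbon bound to a double-bonded chain carbon. Among the compounds with values here, the only measured step at that place is a number 12 percentage points lower from compound 1 to compound 2 (beyond the scatter) and it involves another group, so it suggests a possible size but no firm direction. A small rise within the scatter is expected, and the estimated step is a number 6 percentage points higher from compound 2 to compound 3 (within the scatter) on this reasoning. Compound 3 is estimated at 60% with 46% to 74% as the expected range.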

Compound 3, percent growth inhibition at one concentration: 76%
Beside the measured number, compound 3's estimate is 16 percentage points below it; the whole stated range lies below it.
By their numbers in this assay, from the lowest: compound 2; then compounds 1 and 3 (each within the scatter of the next).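

In this assay, 3,4,5-trimethoxyphenyl in place of 4-methoxyphenyl gives a number 22 percentage points higher from compound 2 to compound 3 (beyond the scatter), showing that this position can move the read-out upward as well as downward. Set against naphthalen-1-yl, the same group gives a number 10 percentage points higher from compound 1 to compound 3 (within the scatter), so these two groups cannot be separated at this place. Nothing available explains either step.

As far as these compounds go, whether all three methoxy groups are needed for the rise remains open. So does how a phenyl ring carrying an amine or a carboxylic acid would read at this place.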